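Chloro in place of cyano on the aryl group of compound 3

The source may hold more compounds than are shown below. What is called first, only, known or untested is meant among the compounds shown, and "the series" means these compounds.

Measured compounds:
compound 1, `COc1ccc(-n2c(C)nc3c(NC(C4CC4)C4CC4)nc(C)nc32)cc1`: 19 nM
compound 2, `COCc1nc2c(NC(C3CC3)C3CC3)nc(C)nc2n1-c1ccc(OC)cc1`: 157 nM
compound 3, `Cc1nc(NC(C2CC2)C2CC2)c2nc(C)n(-c3ccc(C#N)cc3)c2n1`: 62 nM

In a functional assay on CHO cells for antagonist activity at corticotropin-releasing factor receptor 1 (Homo sapiens), read by cAMP accumulation (on this read-out higher numbers stand for weaker inhibition and lower numbers for stronger inhibition), compound 3 stands second highest of the three numbers. Its nearest neighbour is compound 2, which gives 157 nM, a higher number than compound 3 and beyond the scatter; the furthest is compound 1, which gives 19 nM, a lower number and likewise beyond the scatter.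

Compound 4, `Cc1nc(NC(C2CC2)C2CC2)c2nc(C)n(-c3ccc(Cl)cc3)c2n1`, differs from compound 3 in one place: chloro in place of cyano on an aromatic carbon. Within the data shown here, only one measured step touches this position, a 3.3-fold higher number from compound 1 to compound 3 (0.51 log units; beyond the scatter), which shows that the group on this aromatic carbon moves the number by a modest amount. The other step, an 8.3-fold higher number from compound 1 to compound 2 (0.92 log units; beyond the scatter), concerns a saturated chain carbon elsewhere in the molecule and says nothing about this aryl substituent. Among the measured compounds shown here, no measured compound carries chloro at this place, so the direction of the step rests on thin ground.

Compound 4 is therefore expected to land close to compound 3, with an estimated step of a 1.6-fold lower number from compound 3 to compound 4 (0.19 log units; within the scatter) in this assay. The estimate for compound 4 is 40 nM, with a range from 14 nM to 115 nM.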

Compound 4, inhibition constant: 11 nM
Estimate against measurement, compound 4: 3.6-fold (0.56 log units) above; the measured number lies below the stated range.
By their numbers in this assay, from the lowest: compounds 4 and 1 (each within the scatter of the next); then compound 3; then compound 2.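

In this assay, among these compounds, the change from 4-cyanophenyl to 4-chlorophenyl gives a 5.6-fold lower number from compound 3 to compound 4 (0.75 log units; beyond the scatter), so the earlier 3.3-fold higher number from compound 1 to compound 3 (0.51 log units; beyond the scatter) no longer stands alone as the only reading of this aromatic carbon: the nitrile now differs from two other groups at the same place, not from methoxy only. Chloro and methoxy, on the other hand, cannot be told apart here, with a 1.7-fold lower number from compound 1 to compound 4 (0.24 log units; within the scatter), so among these three groups on the aryl ring, para to a large group, the nitrile alone goes with a higher number, and swapping methoxy for chloro leaves the result within the usual scatter. The data shown offer no measured explanation for why the nitrile stands apart from the other two groups.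

The compounds shown leave open whether other groups at this place, such as fluoro, methyl or a dimethylamino group, would sit with chloro and methoxy or with the nitrile. They also leave open whether the chloro-bearing aryl group would hold its number in a compound that carries the extra methoxy on the chain carbon, as compound 2 does.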